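The source may hold more compounds than are shown below. What is called first, only, known or untested is meant among the compounds shown, and "the series" means these compounds.

Compound 1 `O=C(CSc1snnc1-c1ccc(Br)cc1Br)Nc1cccnc1Cl`: in an ADME assay on MT4 cells (Homo sapiens) for cytotoxicity, read by MTT assay, with a stated time of 5 days (on this read-out lower numbers stand for higher toxicity in this test and higher numbers for lower toxicity in this test), compound 1 gives > 240000 nM, which is a limit of the assay.
Compound 2 `O=C(CSc1snnc1-c1ccc(Br)cc1Br)Nc1ccccc1`: in this assay compound 2 gives 24800 nM.

Compound 2 carries the only number shown; the entry for compound 1 is a limit (the limit of > 240000 nM in this assay, at which 1 of the 2 values shown sits). Among the measured compounds shown here, the single measured step, an at least 9.6-fold lower number from compound 1 to compound 2 (0.98 log units; beyond the scatter), sits on the same amide-type nitrogen as the change to compound 3 `Cc1cccc(NC(=O)CSc2snnc2-c2ccc(Br)cc2Br)c1C`, namely (2,3-dimethylphenyl in place of phenyl on an amide-type nitrogen). That measured step exchanged one aryl for another; the present change only adds two methyl groups to the phenyl and so gives no direct guide. No step beyond the scatter is expected, and compound 3 is estimated at 20000 nM (range 7000 nM to 60000 nM), a step of a 1.2-fold lower number from compound 2 to compound 3 (0.09 log units; within the scatter).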

Compound 3, half-maximal cytotoxic concentration: 241000 nM
Compound 3: middle estimate off by 12-fold (1.08 log units), on the low side; the measured number lies above the stated range.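

On the amide-type nitrogen, two added methyl groups are enough to move the read-out: 2,3-dimethylphenyl in place of phenyl gives a 9.7-fold higher number from compound 2 to compound 3 (0.99 log units; beyond the scatter) in this assay. The lower number of compound 2 therefore does not follow from a ring of carbon only, since compound 3 carries such a ring as well. The step from compound 1 to compound 3 cannot be read: the limit of > 240000 nM in this assay, at which 1 of the 3 values shown sits.

Open, as far as these compounds go, is whether 2-methylphenyl or 3-methylphenyl alone accounts for the step. Also open, from the compounds shown here alone, is whether a methoxy group or an amine on the phenyl gives a similar step.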